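The source may hold more compounds than are shown below. What is called first, only, known or untested is meant among the compounds shown, and "the series" means these compounds.

The series is a set of four compounds built on one shared core, differing in the saturated ring fused to it and in the substituent on the aromatic ring at the far end of the chain. Compound 1 `NC1=NC2(CCSCC2)N(OCCCOc2cccc(Cl)c2Cl)C(N)=N1` and compound 3 `COc1ccc(OCCCON2C(N)=NC(N)=NC23CCSCC3)cc1` carry a sulfur-containing saturated ring; in an assay on isolated protein for inhibition of Dihydrofolate reductase (Homo sapiens), read by spectrophotometry, using NADPH, with stated times of 5 s and 6 min (a lower number here means a stronger inhibitor, a higher number a weaker inhibitor), compound 1 gives "not determined" (no result reported) and compound 3 gives "not determined" (no result reported), so neither contributes a number. Compound 2 `NC1=NC2(CCOCC2)N(OCCCOc2ccc(Cl)cc2)C(N)=N1` carries an oxygen-containing saturated ring, and in this assay compound 2 gives 33.6 nM. Within the data shown here, compound 2 therefore stands alone: it is the only compound of the series with a reported number, and there is no second number to place it against.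

Compound 4 `NC1=NC2(CCOCC2)N(OCCCOc2ccccc2)C(N)=N1` differs from compound 2 in one place: hydrogen in place of chloro on an aromatic carbon. Among the measured compounds shown here, since no measured pair shows what a change of this kind does here, the expected size of the step rests on the change itself. A chlorine removed from the aromatic ring is expected to cost a modest amount of potency, with a step from compound 2 to compound 4 of a 2.2-fold higher number from compound 2 to compound 4 (0.35 log units; beyond the scatter) expected in this assay, somewhat beyond the usual scatter but not by a wide margin. Compound 4 is thus estimated at 75 nM in this assay, within a range of 30 nM to 190 nM.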

Compound 4, half-maximal inhibitory concentration: 86.1 nM
Estimate against measurement, compound 4: 1.1-fold (0.06 log units) below; measured number inside the range.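

Among these compounds, with compound 4 the series gains its first measured pair, and with it the first direct reading of this position. In this assay the change from 4-chlorophenyl to phenyl gives a 2.6-fold higher number from compound 2 to compound 4 (0.41 log units; beyond the scatter) and this step is modest, so the chloro on the aromatic carbon para to a large group counts for something in this assay, yet inhibition stays measurable with hydrogen in its place. Compound 2 on its own could show neither the direction nor the size of this change, and nothing at hand gives a reason for the size of the step.

The compounds shown leave open whether another group in the same place, such as a nitrile or an amine, would give a number closer to that of compound 2 or to that of compound 4. They also leave open whether the step would keep its size with the sulfur-containing saturated ring in place of the oxygen-containing one, or with a longer chain leading to the aromatic ring.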